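This account rests on a few compounds, and the source may have more. Where it says the series, first, only, none or still open, it means among the compounds named here.

Three compounds share one core and differ only in the aryl group on the ring nitrogen. Compound 1 `Cc1ccccc1Nc1nc(SCc2ccc(C(F)(F)F)cc2)nc2ccccc12` gives 24400 nM in a functional assay on MGC-803 cells (Homo sapiens) for cytotoxicity, read by MTT assay, with a stated time of 72 h; a lower number here means a stronger inhibitor, a higher number a weaker inhibitor. Compound 2 `FC(F)(F)c1ccc(CSc2nc(Nc3cccc(C(F)(F)F)c3)c3ccccc3n2)cc1` gives 15100 nM. Compound 3 `FC(F)(F)c1ccc(CSc2nc(Nc3cccc(Cl)c3)c3ccccc3n2)cc1` gives 14600 nM, the smallest of the three numbers shown, yet a 1.7-fold lower number from compound 1 to compound 3 (0.22 log units; within the scatter) and a 1.0-fold lower number from compound 2 to compound 3 (0.01 log units; within the scatter) both keep it inside the scatter, as does a 1.6-fold lower number from compound 1 to compound 2 (0.21 log units; within the scatter). Compound 4 `FC(F)(F)c1ccc(CSc2nc(Nc3ccc(C(F)(F)F)cc3)c3ccccc3n2)cc1` differs from compound 3 by 4-(trifluoromethyl)phenyl in place of 3-chlorophenyl on a nitrogen on an aromatic ring. The measured steps that bear on this change all swap the same aryl group, and none of them moved this assay beyond its scatter, so nothing beyond the scatter is expected here either. Compound 4 is therefore estimated at about 14000 nM, within 6000 nM to 32000 nM, meaning an expected 1.0-fold lower number from compound 3 to compound 4 (0.02 log units; within the scatter).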

Compound 4, half-maximal inhibitory concentration: 6170 nM
Compound 4: middle estimate off by 2.3-fold (0.36 log units), on the high side, and the stated range covers the measured number.
By their numbers in this assay, from the lowest: compound 4; then compounds 3, 2 and 1 (each within the scatter of the next).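

In this assay the aryl group on this nitrogen now matters beyond the scatter, with a 2.4-fold lower number from compound 3 to compound 4 (0.37 log units; beyond the scatter) and a 4.0-fold lower number from compound 1 to compound 4 (0.60 log units; beyond the scatter). Moving the trifluoromethyl alone, 4-(trifluoromethyl)phenyl in place of 3-(trifluoromethyl)phenyl, gives a 2.4-fold lower number from compound 2 to compound 4 (0.39 log units; beyond the scatter), so the change is modest but is seen even between these two closely matched groups. Nothing shown explains this difference.

Still open, on these data alone, is whether an amine or a carboxylic acid in place of that trifluoromethyl would keep the gain. The compounds also leave open whether a methoxy group there would do the same.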